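The source may report more compounds than this note shows. Statements on the series, on what has been measured and on what is new or still open speak of the compounds shown alone.

Compound 1 `Cc1cccc(NC(=O)COc2ccc3cc(/C=C4/SC(=O)NC4=O)ccc3c2)n1` gives 1100 nM in an assay on isolated protein for inhibition of histone deacetylase 4 (Homo sapiens), with a stated time of 1 h (on this read-out higher numbers stand for weaker inhibition and lower numbers for stronger inhibition), and shows the lowest number among the three measured compounds. Compound 2 `Cc1cccc2sc(NC(=O)COc3ccc4cc(/C=C5/SC(=O)NC5=O)ccc4c3)nc12` gives 1200 nM, and compound 3 `O=C(COc1ccc2ccccc2c1/C=C1\SC(=O)NC1=O)Nc1ccc([N+](=O)[O-])cc1` gives 15000 nM; between compound 1 and compound 3 the two values differ by far more than the scatter, while no single-point change links them. The change from compound 1 to compound 4 `O=C(COc1ccc2cc(/C=C3/SC(=O)NC3=O)ccc2c1)Nc1ccccc1` is phenyl in place of 6-methylpyridin-2-yl on an amide-type nitrogen. Among the compounds with values here, the only measured step at this position is a 1.1-fold higher number from compound 1 to compound 2 (0.04 log units; within the scatter), where a larger heteroaromatic group replaced the 6-methylpyridin-2-yl without moving the number beyond the scatter. Because of a 1.1-fold higher number from compound 1 to compound 2 (0.04 log units; within the scatter) the amide-type nitrogen appears to accept different aryl groups, and a step of a 1.4-fold higher number from compound 1 to compound 4 (0.13 log units; within the scatter) is therefore expected, that is none clearly beyond the scatter, perhaps slightly weaker inhibition. Compound 4 is estimated at 1500 nM, with a range from 600 nM to 4000 nM in this assay.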

Compound 4, half-maximal inhibitory concentration: 2100 nM
Compound 4: the middle estimate sits 1.4-fold (0.15 log units) below what was measured; measured number inside the range.
By their numbers in this assay, from the lowest: compounds 1, 2 and 4 (each within the scatter of the next); then compound 3.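

Phenyl in place of 6-methylpyridin-2-yl gives a 1.9-fold higher number from compound 1 to compound 4 (0.28 log units; within the scatter) and phenyl in place of 4-methyl-1,3-benzothiazol-2-yl gives a 1.8-fold higher number from compound 2 to compound 4 (0.24 log units; within the scatter) in this assay on this amide-type nitrogen. Both steps stay within the scatter, so a six-membered aromatic ring of carbon only now stands here alongside the two groups that hold a ring nitrogen, and a ring nitrogen in this group is not required for a number in this range. Nothing measured here explains why these three groups read alike.

From the compounds shown here alone, whether a saturated ring such as cyclohexyl, or a phenyl carrying an amine or a carboxylic acid, would keep the number in this range stays open. The compounds shown also offer no single-place step for the nitro-bearing aryl group of compound 3.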